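Cytotoxicity notes on three measured analogues and one pending

The compounds below may be only part of what the source reports. "The series", "measured", "known", "first", "only" and "open" are said of these compounds alone.

Compound 1 `Cc1ccc(NCc2cn(-c3ccccc3)nc2-c2ccc(C(F)(F)F)cc2)cc1` — in an ADME assay on MT4 cells (Homo sapiens) for cytotoxicity, read by MTT assay, with a stated time of 96 h (on this read-out higher numbers stand for lower toxicity in this test and lower numbers for higher toxicity in this test), compound 1 gives > 100000 nM, which is a limit of the assay, not a number.
Compound 2 `FC(F)(F)c1ccc(NCc2cn(-c3ccccc3)nc2-c2ccc(C(F)(F)F)cc2)cc1` — in this assay compound 2 gives > 100000 nM, again a limit.
Compound 3 `Cc1ccc(NCc2cn(-c3ccccc3)nc2-c2ccccc2)cc1` — in this assay compound 3 gives > 100000 nM, also a limit.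

Compound 2 differs from compound 1 by trifluoromethyl in place of methyl on an aromatic carbon; the step is a step that the two limits leave unreadable from compound 1 to compound 2. The two cores differ by hydrogen in place of trifluoromethyl on an aromatic carbon; that step is a step that the two limits leave unreadable from compound 1 to compound 3. All three values stand at the limit of > 100000 nM in this assay, at which 3 of the 3 values shown sit, so neither change can be sized.

Compound 4 `FC(F)(F)c1ccc(NCc2cn(-c3ccccc3)nc2-c2ccccc2)cc1` awaits measurement. It differs from compound 3 by trifluoromethyl in place of methyl on an aromatic carbon, the same change as from compound 1 to compound 2. The step of a number no higher from compound 3 to compound 4 (the limit leaves the size open) is expected to be small, resting on compound 1 and compound 2 both sitting at the limit of > 100000 nM in this assay, at which 3 of the 3 values shown sit. Compound 4 in this assay is expected near 100000 nM, most likely reported again only as a limit.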

Compound 4, half-maximal cytotoxic concentration: > 100000 nM
Compound 4: only a limit was reported; the forecaster's own chance of this, stated with the estimate: 85%; the middle value sits exactly at the limit.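

The steps from compound 3 to compound 4 and from compound 2 to compound 4 cannot be read, since each joins two limits: the limit of > 100000 nM in this assay, at which 4 of the 4 values shown sit. The compounds shown leave open where cytotoxicity would begin in this assay, and whether either change affects it.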